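This account rests on a few compounds, and the source may have more. Where it says the series, first, only, none or still open, it means among the compounds named here.

Compound 1 `NC(=O)c1c(NC(=O)c2ccccc2F)sc2c1CCN(C(=S)Nc1cc(C(F)(F)F)cc(C(F)(F)F)c1)C2` gives 13300 nM in a functional assay on MKN-74 cells (Homo sapiens) for antiproliferative activity, with a stated time of 24 h; on this read-out higher numbers stand for weaker inhibition and lower numbers for stronger inhibition. Compound 2 `NC(=O)c1c(NC(=O)c2ccc(C(F)(F)F)cc2)sc2c1CCN(C(=S)Nc1cc(C(F)(F)F)cc(C(F)(F)F)c1)C2` gives 13800 nM in this assay.

On these two numbers compound 2 and compound 1 sit within the scatter of each other, the step being a 1.0-fold higher number from compound 1 to compound 2 (0.02 log units; within the scatter). Compound 3 `NC(=O)c1c(NC(=O)c2cccc([N+](=O)[O-])c2)sc2c1CCN(C(=S)Nc1cc(C(F)(F)F)cc(C(F)(F)F)c1)C2` differs from compound 2 by 3-nitrophenyl in place of 4-(trifluoromethyl)phenyl on a carbonyl carbon. Among the measured compounds shown here, the only measured step that bears on this place, a 1.0-fold higher number from compound 1 to compound 2 (0.02 log units; within the scatter), changed the group on the same carbonyl carbon and stayed within the scatter. Compound 3 is therefore expected to show no step beyond the scatter, a 1.1-fold lower number from compound 2 to compound 3 (0.03 log units; within the scatter). The estimate for compound 3 in this assay is 13000 nM, with a range from 5000 nM to 35000 nM.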

Compound 3, half-maximal inhibitory concentration: 25800 nM
Estimate against measurement, compound 3: 2.0-fold (0.30 log units) below, and the stated range covers the measured number.
By their numbers in this assay, from the lowest: compounds 1, 2 and 3 (each within the scatter of the next).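

In this assay, 3-nitrophenyl on this carbonyl carbon stays within the scatter of both earlier groups, with a 1.9-fold higher number from compound 2 to compound 3 (0.27 log units; within the scatter) and a 1.9-fold higher number from compound 1 to compound 3 (0.29 log units; within the scatter). Among the compounds shown here, this place has now carried three differently substituted phenyl groups, and no step among them lies beyond the scatter. Nothing available here accounts for these numbers.

As far as these compounds go, it remains open whether a group of another kind on this carbonyl carbon, such as an aminomethyl, a carboxylic acid or a cyclohexyl ring, would give a step beyond the scatter, and in which direction.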